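Turning One Stereocentre on a Weak Inhibitor

A few compounds are considered here, and "the series" means these few. Any claim that something is new, unique, unknown or untested is made for them only; others in the source may bear on it.

In a functional assay, with a stated time of 30 min (a higher number here means a weaker inhibitor, a lower number a stronger inhibitor), compound 1 (`COc1cc([C@@H](O)[C@H](CO)Oc2c(OC)cc([C@@H](O)[C@H](O)CO)cc2OC)ccc1O`) gives 114000 nM as its reading and compound 2 (`COc1cc([C@H](OC)[C@@H](CO)Oc2ccc([C@@H](O)[C@H](O)CO)cc2OC)ccc1O`) gives 109000 nM as its reading, so the two sit within the scatter of each other. Compound 3 (`COc1cc([C@@H](O)[C@@H](CO)Oc2c(OC)cc([C@@H](O)[C@H](O)CO)cc2OC)ccc1O`) differs from compound 1 only in configuration as drawn (the two compounds have the same atoms and bonds and differ only in configuration as drawn: 1 of 4 stereo elements differ; a stereocentre at a saturated chain carbon is drawn S in compound 1 and R in compound 3). Going by the values given here, no measured pair shows what such a change does, so in this assay no step beyond the scatter is expected, in either direction. The expected change is small (a 1.1-fold lower number from compound 1 to compound 3 (0.06 log units; within the scatter)). Compound 3 is estimated at 100000 nM (range 40000 nM to 250000 nM).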

Compound 3, half-maximal inhibitory concentration: 138000 nM
Compound 3: the middle estimate sits 1.4-fold (0.14 log units) below what was measured; the measured number falls inside the stated range.
By their numbers in this assay, from the lowest: compounds 2, 1 and 3 (each within the scatter of the next).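

In this assay, redrawing the stereocentre at this saturated chain carbon from S to R gives a 1.2-fold higher number from compound 1 to compound 3 (0.08 log units; within the scatter). Going by these compounds alone, this is the first measured pair to test such a change, and at this position the two readings cannot be told apart. The comparison is a clean one, since nothing else separates the two structures: the fact that compounds 1 and 3 differ only in the configuration as drawn

Going by these compounds, whether the other stereo elements would matter as little remains open. So does what an amine or a carboxylic acid in place of a hydroxyl group would do to the reading.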